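Series notes: the step from compound 1 to compound 4

A few compounds are considered here, and "the series" means these few. Any claim that something is new, unique, unknown or untested is made for them only; others in the source may bear on it.

Measured compounds:
- compound 1 `COc1ccc(/C=C(/Sc2ccc(Br)cc2)C(=O)c2ccc(Br)cc2)cc1`: 25000 nM
- compound 2 `O=C(/C(=C\c1ccc(Oc2ccccc2)cc1)Sc1ccc(Br)cc1)c1ccc(Br)cc1`: 50000 nM
- compound 3 `COc1ccc(/C=C(/Sc2ccc(C)cc2)C(=O)c2ccc(Br)cc2)cc1`: 50000 nM

In a functional assay on DU-145 cells (Homo sapiens) for inhibition, read by trypan blue exclusion, with a stated time of 96 h (on this read-out lower numbers stand for stronger inhibition of growth and higher numbers for weaker inhibition of growth), compound 1 gives 25000 nM, the lowest of the three numbers; compound 2 and compound 3 sit within the scatter of it, so no order among the three can be read. The two measured steps, a 2.0-fold higher number from compound 1 to compound 2 (0.30 log units; within the scatter) and a 2.0-fold higher number from compound 1 to compound 3 (0.30 log units; within the scatter), both stay within the scatter and both touch places other than the one changed now.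

Compound 4 `O=C(/C(=C\c1ccc(Br)c(O)c1)Sc1ccc(Br)cc1)c1ccc(Br)cc1` differs from compound 1 by 4-bromo-3-hydroxyphenyl in place of 4-methoxyphenyl on a double-bonded chain carbon bound to a double-bonded chain carbon. Within the data shown here, no measured pair changes this group, so nothing speaks directly for or against a shift in this assay. With both known steps within the scatter, the expectation is a step of no change at the digits printed from compound 1 to compound 4 (within the scatter), that is, none beyond the scatter. Compound 4 is therefore estimated at 25000 nM, expected to lie between 8000 nM and 80000 nM.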

Compound 4, concentration for 50% growth inhibition: 1000 nM
The estimate for compound 4 lay 25-fold (1.40 log units) above the measured number, outside the stated range (below it).
By their numbers in this assay, from the lowest: compound 4; then compounds 1, 2 and 3 (each within the scatter of the next).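

In this assay, among these compounds, 4-bromo-3-hydroxyphenyl in place of 4-methoxyphenyl gives a 25-fold lower number from compound 1 to compound 4 (1.40 log units; beyond the scatter), the first step to leave the scatter. The earlier change to this same group, phenyl in place of methyl on the oxygen, gave only a 2.0-fold higher number from compound 1 to compound 2 (0.30 log units; within the scatter), so this position can move the number strongly, but not every change there does so. Nothing at hand accounts for the size of the step.

The entering group differs from the leaving one in two ways at once, with a bromo added and a hydroxy in place of the methoxy, and the compounds shown do not separate the two. As far as these compounds go, whether an amine or a carboxylic acid in place of the hydroxy would keep the low number also stays open.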